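The source may report more compounds than this note shows. Statements on the series, on what has been measured and on what is new or still open speak of the compounds shown alone.

In a functional assay on PANC-1 cells (Homo sapiens) for antiproliferative activity, read by fluorescence and resazurin assay, with a stated time of 48 h (a lower number here means a stronger inhibitor, a higher number a weaker inhibitor), compound 1 `Cc1noc(NS(=O)(=O)c2ccc(NC(=O)c3cc4ccc(O)cc4oc3=O)cc2)c1C` gives 16200 nM, compound 2 `CCOc1ccc2nc(Cl)c(/C=N/NC(=O)c3cc4cc([N+](=O)[O-])ccc4oc3=O)cc2c1` gives 10500 nM and compound 3 `CCOc1ccc(NC(=O)c2cc3ccc(O)cc3oc2=O)cc1` gives 14300 nM. Compound 1 therefore stands with the other two: all three values lie within the scatter of one another, and the numbers do not separate them. The next compound to be tested, compound 4 `Cc1noc(NS(=O)(=O)c2ccc(NC(=O)c3cc4ccccc4oc3=O)cc2)c1C`, differs from compound 1 in one place, with hydrogen in place of hydroxy on an aromatic carbon. For the measured compounds named here, no pair of measured compounds differs in one place only, so no measured step speaks directly to this change. The indirect evidence is limited. Compound 3 keeps the hydroxy group and gives 14300 nM, while compound 2 carries no hydroxy group and gives 10500 nM, a value within the scatter of the former. On that basis, no step beyond the scatter is expected in this assay, and no direction can be favoured with confidence. The estimated change, a 1.0-fold higher number from compound 1 to compound 4 (0.02 log units; within the scatter), is accordingly expected to be small. Compound 4 is estimated at 17000 nM, with an expected range from 8000 nM to 40000 nM.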

Compound 4, half-maximal inhibitory concentration: 19900 nM
For compound 4 the middle estimate is 1.2-fold (0.07 log units) below the measured one; measured number inside the range.
By their numbers in this assay, from the lowest: compounds 2, 3, 1 and 4 (each within the scatter of the next).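

For the compounds shown here, the comparison of compound 1 with compound 4 gives the first direct reading of this change in this assay: a 1.2-fold higher number from compound 1 to compound 4 (0.09 log units; within the scatter). Going by these compounds alone, on this core, then, the numbers do not separate hydrogen from hydroxy on this aromatic carbon, which is part of a fused system of two rings, meta to a fused ring and para to a fused ring, whereas the earlier compounds offered only an indirect view across structures differing in more than one place. No measurement shown offers a reason for this outcome or shows what the hydroxy group does in these cells.

From the compounds shown here alone, it remains open whether a different group at this same place, such as methoxy, an amine or a carboxylic acid, would give a step beyond the scatter in this assay, in either direction. Going by these compounds, it is also open whether the same exchange of hydroxy for hydrogen would read alike on the core of compound 3, since this single pair speaks only for the core it shares.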